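Swapping one small ring for another on the chloro-bearing ring

The source may report more compounds than this note shows. Statements on the series, on what has been measured and on what is new or still open speak of the compounds shown alone.

Three compounds share one core and differ only in a small ring attached to a chloro-bearing benzene. Compound 1 `Cn1nc2c(=O)n(CC3(O)CCN(Cc4ccc(-n5ccnc5)cc4Cl)CC3)cnc2c1-c1ccc(CN)cc1` gives 228 nM in an assay on isolated protein for inhibition of ubiquitin carboxyl-terminal hydrolase 7 (Homo sapiens), with stated times of 30 min and 2 h; on this read-out higher numbers stand for weaker inhibition and lower numbers for stronger inhibition. Compound 2 `Cn1nc2c(=O)n(CC3(O)CCN(Cc4ccc(-c5ncco5)cc4Cl)CC3)cnc2c1-c1ccc(CN)cc1` gives 1120 nM, and compound 3 `Cn1nc2c(=O)n(CC3(O)CCN(Cc4ccc(-c5ccoc5)cc4Cl)CC3)cnc2c1-c1ccc(CN)cc1` gives 177 nM. Compound 3 and compound 1 lie within the scatter of each other, as the step of a 1.3-fold lower number from compound 1 to compound 3 (0.11 log units; within the scatter) shows, while both sit clearly below compound 2: the steps were a 4.9-fold higher number from compound 1 to compound 2 (0.69 log units; beyond the scatter) and a 6.3-fold lower number from compound 2 to compound 3 (0.80 log units; beyond the scatter).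

Compound 4 `Cn1nc2c(=O)n(CC3(O)CCN(Cc4ccc(-c5cccs5)cc4Cl)CC3)cnc2c1-c1ccc(CN)cc1` is the next member. Its difference from compound 3 is thiophen-2-yl in place of furan-3-yl on an aromatic carbon. Among the measured compounds shown here, no measured step exchanges these two particular rings, so the bearing of the earlier steps is indirect: one exchange of small ring moved the number within the scatter, the other moved it modestly. A step no larger than modest, in either direction, is therefore the expectation, and the most likely outcome is little change, a 1.1-fold higher number from compound 3 to compound 4 (0.05 log units; within the scatter). Compound 4 is accordingly estimated at 200 nM in this assay, in a range from 90 nM to 450 nM.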

Compound 4, half-maximal inhibitory concentration: 38.6 nM
Beside the measured number, compound 4's estimate is 5.2-fold (0.71 log units) above it; the whole stated range lies above it.
By their numbers in this assay, from the lowest: compound 4; then compounds 3 and 1 (each within the scatter of the next); then compound 2.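

Thiophen-2-yl at this position, para to a large group, gives the lowest number of the four in this assay, with a 4.6-fold lower number from compound 3 to compound 4 (0.66 log units; beyond the scatter) and a 5.9-fold lower number from compound 1 to compound 4 (0.77 log units; beyond the scatter) and also a 29-fold lower number from compound 2 to compound 4 (1.46 log units; beyond the scatter) in the series. Furan-3-yl and thiophen-2-yl have the same counts of heavy atoms, hetero atoms, hydrogen-bond donors and hydrogen-bond acceptors, so the earlier compounds' lesson is extended: even an exchange these counts do not register can move the number beyond the scatter. Nothing available explains this gain.

Two things change together here, the hetero atom and the place where the ring is attached, and furan-2-yl or thiophen-3-yl would be needed to tell them apart. Going by these compounds, whether a six-membered ring such as phenyl or pyridin-3-yl fits this position as well also remains open.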